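Adding a Benzoyl Group to Compound 1

A few compounds are considered here, and "the series" means these few. Any claim that something is new, unique, unknown or untested is made for them only; others in the source may bear on it.

Of the compounds shown here, two have been measured in a functional assay on Raji cells (Homo sapiens) for antiproliferative activity, read by MTT assay, with a stated time of 72 h; on this read-out lower numbers stand for stronger inhibition and higher numbers for weaker inhibition. Compound 1, `O=C1C[C@H]2O[C@H]([C@H](O)c3ccccc3)[C@H](O)[C@H]2O1`, gives 18500 nM, the higher of the two numbers. Compound 2, `O=C1CC[C@@H]([C@@H](O)[C@H](O)[C@H](O)c2ccccc2)O1`, gives 2210 nM, which lies beyond the scatter below compound 1. Compound 3, `O=C1C[C@H]2O[C@H]([C@H](OC(=O)c3ccccc3)c3ccccc3)[C@H](O)[C@H]2O1`, has not yet been measured; it differs from compound 1 by benzoyl in place of hydrogen on an oxygen on a saturated carbon. Among the measured compounds shown here, no measured pair here shows what this change does. The expected step is a 3.1-fold lower number from compound 1 to compound 3 (0.49 log units; beyond the scatter), a lowering of the number that may just pass the scatter. Compound 3 is estimated at 6000 nM, within a range from 1500 nM to 25000 nM.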

Compound 3, half-maximal inhibitory concentration: 1010 nM
Estimate against measurement, compound 3: 5.9-fold (0.77 log units) above; the whole stated range lies above it.
By their numbers in this assay, from the lowest: compound 3; then compound 2; then compound 1.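

Among the compounds shown here, replacing this hydrogen with benzoyl brings an 18-fold lower number from compound 1 to compound 3 (1.26 log units; beyond the scatter), a large step, and it is the first measured change at this oxygen on a saturated carbon. The position therefore tolerates a much bigger group than hydrogen, and here the bigger group goes with stronger inhibition. Nothing available explains why.

Going by these compounds, it remains open whether the step depends on the aromatic ring or on the carbonyl. An acetyl group or a benzyl group on the same oxygen would help separate the two.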